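Two Cores, One Aryl Exchange

The source may hold more compounds than are shown below. What is called first, only, known or untested is meant among the compounds shown, and "the series" means these compounds.

Measured so far in a functional assay on SW480 cells (Homo sapiens) for antiproliferative activity, read by sulforhodamine B assay, with a stated time of 48 h; a higher number here means a weaker inhibitor, a lower number a stronger inhibitor:
compound 1 `COc1cccc(/C=C/C(=O)C(=Cc2ccc(O)c(F)c2)C(=O)/C=C/c2cccc(OC)c2OC)c1OC` gives 330 nM.
compound 2 `COc1cc(C=C(C(=O)/C=C/c2cccc(OC)c2OC)C(=O)/C=C/c2cccc(OC)c2OC)cc(Br)c1O` gives 260 nM.
compound 3 `COc1cc(OC)c(/C=C/C(=O)C(=Cc2ccc(O)c(F)c2)C(=O)/C=C/c2c(OC)cc(OC)cc2OC)c(OC)c1` gives 1950 nM.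

Compounds 1 and 2 share one core, and compound 3 carries a different core; the difference between the two cores is not broken down here. Within the first pair, compound 2 arises from compound 1 by the change (3-bromo-4-hydroxy-5-methoxyphenyl in place of 3-fluoro-4-hydroxyphenyl on a double-bonded chain carbon bound to a double-bonded chain carbon), and in this assay that gave a 1.3-fold lower number from compound 1 to compound 2 (0.10 log units; within the scatter). Compound 3 stands at the highest number of the three: its value lies beyond the scatter from that of compound 1 and from that of compound 2, so on its own core it is the weaker inhibitor of the set.

Compound 4 `COc1cc(OC)c(/C=C/C(=O)C(=Cc2cc(Br)c(O)c(OC)c2)C(=O)/C=C/c2c(OC)cc(OC)cc2OC)c(OC)c1` is not yet measured. It arises from compound 3 by 3-bromo-4-hydroxy-5-methoxyphenyl in place of 3-fluoro-4-hydroxyphenyl on a double-bonded chain carbon bound to a double-bonded chain carbon. The place of the change reads the same, word for word, as in the change from compound 1 to compound 2, so this is the same change applied to the second core. Because the earlier step of a 1.3-fold lower number from compound 1 to compound 2 (0.10 log units; within the scatter) stayed within the scatter, the step from compound 3 to compound 4 is expected to be of similar small size, a 1.3-fold lower number from compound 3 to compound 4 (0.11 log units; within the scatter), although this rests on a single pair and a core that differs. For compound 4 the estimated value in this assay is 1500 nM, expected between 700 nM and 3500 nM.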

Compound 4, half-maximal inhibitory concentration: 1450 nM
Estimate against measurement, compound 4: 1.0-fold (0.01 log units) above, and the stated range covers the measured number.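

In this assay, placing 3-bromo-4-hydroxy-5-methoxyphenyl where 3-fluoro-4-hydroxyphenyl stood, on a double-bonded chain carbon bound to a double-bonded chain carbon, gave a 1.3-fold lower number from compound 3 to compound 4 (0.13 log units; within the scatter). On the second core the exchange therefore behaves as it did on the first, and the two steps agree in size: the same change on two cores in this assay, a 1.3-fold lower number (0.10 log units; within the scatter) from compound 1 to compound 2 and a 1.3-fold lower number (0.13 log units; within the scatter) from compound 3 to compound 4, 1.1-fold (0.03 log units) apart, within the scatter of two such steps. This shows that, for these two pairs, the exchange of aryl groups carries from one core to the other without a change that can be told from the scatter, yet neither step can be told from the scatter itself, so what carries over is a lack of visible effect and not a shift of known size, and two pairs say nothing about any further core.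

The compounds shown leave open whether the insensitivity belongs to this one exchange or to the aryl position in general, since both groups in that place are halogenated phenyl rings that keep their hydroxy group. An amine or a carboxylic acid on that ring in place of the hydroxy group, or a ring with no halogen at all, might read differently on either core.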